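The compounds below may be only part of what the source reports. "The series", "measured", "known", "first", "only" and "open" are said of these compounds alone.

Measured so far in a functional assay on HepG2 cells (Homo sapiens) for inhibition, read by MTT assay, with a stated time of 72 h; on this read-out higher numbers stand for weaker inhibition and lower numbers for stronger inhibition:

- compound 1 `C=C(c1ccc(Cl)c(Cl)c1Cl)C1COC2(CCCC2)OO1`: 8450 nM
- compound 2 `C=C(c1ccc(Cl)cc1Cl)C1COC2(CCCC2)OO1`: 15700 nM
- compound 3 `C=C(c1ccc(F)c(F)c1)C1COC2(CCCCC2)OO1`: 28600 nM

Compound 3 at 28600 nM lies within the scatter of compound 2 at 15700 nM, and its number is clearly higher than that of compound 1 at 8450 nM. Compound 4 `C=C(c1ccc(OC)c(F)c1)C1COC2(CCCCC2)OO1` has methoxy in place of fluoro on an aromatic carbon. Among the measured compounds shown here, no measured step makes this swap. For the measured compounds named here, the only measured step, a 1.9-fold higher number from compound 1 to compound 2 (0.27 log units; within the scatter), replaces chloro with hydrogen, so it is weak guidance and gives no direction. No shift beyond the scatter is therefore expected in this assay, and the expected change is a 1.1-fold lower number from compound 3 to compound 4 (0.06 log units; within the scatter). For compound 4 the estimate is 25000 nM, with an expected range from 10000 nM to 60000 nM.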

Compound 4, half-maximal inhibitory concentration: 13100 nM
Compound 4: the middle estimate sits 1.9-fold (0.28 log units) above what was measured, and the stated range covers the measured number.
By their numbers in this assay, from the lowest: compounds 1, 4, 2 and 3 (each within the scatter of the next, the first and the last beyond it).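

In this assay the swap of methoxy for fluoro on this aromatic carbon, para to a large group, gives a 2.2-fold lower number from compound 3 to compound 4 (0.34 log units; beyond the scatter) as a modest step beyond the usual scatter. So this position responds to a change of group, and here the larger group with a hydrogen-bond acceptor goes with the lower number. Nothing available explains why the number falls.

The compounds shown leave open whether an ethoxy group or an amine on the same carbon would lower the number further. They also leave open whether methoxy would have the same effect without the neighbouring fluoro group.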